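Replacing the amide side chain of compound 2

The source may report more compounds than this note shows. Statements on the series, on what has been measured and on what is new or still open speak of the compounds shown alone.

Measured so far in an ADME assay on L02 cells (Homo sapiens) for antiproliferative activity, read by MTT assay, with a stated time of 48 h; on this read-out higher numbers stand for weaker inhibition and lower numbers for stronger inhibition
- compound 1 `CCn1c(C(=O)NCCCN(C)C)ccc1C(CC)(CC)c1ccc(OCCC(O)(CC)CC)c(C)c1` gives 2420 nM
- compound 2 `CCn1c(C(=O)NCCN(C)C)ccc1C(CC)(CC)c1ccc(OCCC(O)(CC)CC)c(C)c1` gives 990 nM
- compound 3 `CCN(CC)CCNC(=O)c1ccc(C(CC)(CC)c2ccc(OCCC(O)(CC)CC)c(C)c2)n1CC` gives 2290 nM

Compound 2 holds the lowest number of the three. Compound 4 `CCn1c(C(=O)N(CCC#N)CCC#N)ccc1C(CC)(CC)c1ccc(OCCC(O)(CC)CC)c(C)c1` differs from it as follows: a group of 9 heavy atoms (6 carbon, 3 nitrogen; no ring) in place of a group of 6 heavy atoms (4 carbon, 2 nitrogen; no ring), on a carbonyl carbon and no measurement exists yet. The nearest evidence is a 2.4-fold lower number from compound 1 to compound 2 (0.39 log units; beyond the scatter) and a 2.3-fold higher number from compound 2 to compound 3 (0.36 log units; beyond the scatter) in this assay and both are modest, while a 1.1-fold lower number from compound 1 to compound 3 (0.02 log units; within the scatter) stays within the scatter. None of these steps replaces the whole group, so they guide the expectation only loosely. An upward move of modest or somewhat larger size is expected, as compound 2 at 990 nM is the lowest so far. The expected change is a 4.0-fold higher number from compound 2 to compound 4 (0.61 log units; beyond the scatter) on this estimate. For compound 4 the estimated value is 4000 nM with an expected range from 1500 nM to 15000 nM in this assay overall.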

Compound 4, half-maximal inhibitory concentration: 37800 nM
Estimate against measurement, compound 4: 9.5-fold (0.98 log units) below; measured number outside the range, above it.
By their numbers in this assay, from the lowest: compound 2; then compounds 3 and 1 (each within the scatter of the next); then compound 4.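

For the compounds shown here, at the carbonyl carbon, the entering group with 2 triple bonds outside aromatic rings and 0 hydrogen-bond donors gives the largest steps so far in this assay (a 38-fold higher number from compound 2 to compound 4 (1.58 log units; beyond the scatter); a 17-fold higher number from compound 3 to compound 4 (1.22 log units; beyond the scatter); a 16-fold higher number from compound 1 to compound 4 (1.19 log units; beyond the scatter)). Changes among the three amino side chains moved the number far less, so this position is clearly sensitive to a change of the whole group. No measurement shown bears on the cause of this rise. 

From the compounds shown here alone, it remains open whether the rise follows from the loss of the amide hydrogen, of the terminal amine, or from the nitrile groups. A single 2-cyanoethyl group on the amide nitrogen, or a morpholine-bearing chain, would help separate these.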